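The source may hold more compounds than are shown below. What is called first, only, known or untested is meant among the compounds shown, and "the series" means these compounds.

In an ADME assay on HEK-293T cells (Homo sapiens) for cytotoxicity, read by MTT assay, with a stated time of 3 days (on this read-out lower numbers stand for higher toxicity in this test and higher numbers for lower toxicity in this test), compound 1 `CC(C)(C)NC(=O)COC(=O)c1ccc([N+](=O)[O-])o1` reads > 100000 nM, which is a limit and not a number. Compound 2 `CC(C)(C)N(Cc1cccc([N+](=O)[O-])c1)C(=O)COC(=O)c1ccc([N+](=O)[O-])o1` gives a true number, 78000 nM. Compound 3 `CC(=O)Oc1ccccc1CN(C(=O)COC(=O)c1ccc([N+](=O)[O-])o1)C(C)(C)C` reads > 100000 nM, again only a limit, so its position is known from one side alone. Among the measured compounds shown here, the series so far sits close to that ceiling: the limit of > 100000 nM in this assay, at which 2 of the 3 values shown sit. Compound 4 `COc1ccc(CN(C(=O)COC(=O)c2ccc([N+](=O)[O-])o2)C(C)(C)C)cc1` has 4-methoxyphenyl in place of 2-acetoxyphenyl on a saturated chain carbon bound to an amide-type nitrogen. For the measured compounds named here, the only measured change at this place is an at least 1.2-fold higher number from compound 2 to compound 3 (0.10 log units; that floor lies within the scatter), and its true size remains open. No step beyond the scatter is therefore expected, and the estimated step is an at least 1.1-fold lower number from compound 3 to compound 4 (0.04 log units; that floor lies within the scatter). For compound 4 the estimated value is 90000 nM, with an expected range from 40000 nM to 170000 nM.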

Compound 4, half-maximal cytotoxic concentration: > 100000 nM
Compound 4: a limit, no number (the forecaster's own chance of this, stated with the estimate: 50%); at least 1.1-fold (0.04 log units) between middle value and limit.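

Among the compounds shown here, a second group at this place, 4-methoxyphenyl, gives an at least 1.2-fold higher number from compound 2 to compound 4 (0.10 log units; that floor lies within the scatter), which leaves compound 2 as the only compound with a true number. The steps from compound 3 and from compound 1 to compound 4 cannot be read. The series now sits even closer to the ceiling: the limit of > 100000 nM in this assay, at which 3 of the 4 values shown sit.

Going by these compounds, how far the true values of compound 3 and compound 4 lie from that limit stays open. So does how an amine or a carboxylic acid on this aromatic ring would read in this assay.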